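The compounds below may be only part of what the source reports. "The series", "measured", "known", "first", "only" and "open" are said of these compounds alone.

Measured in an assay on isolated protein for inhibition of vascular endothelial growth factor receptor 1 (Homo sapiens), read by ELISA, with a stated time of 20 min; on this read-out higher numbers stand for weaker inhibition and lower numbers for stronger inhibition:

Compound 1 `OB(O)c1ccc2ncnc(Nc3ccc(F)c(Cl)c3)c2c1`: > 1000 nM, a limit of the assay rather than a number.
Compound 2 `COc1cc2ncnc(Nc3ccc(F)c(Cl)c3)c2cc1B(O)O`: > 1000 nM, again only a limit.
Compound 3 `OB(O)c1ccc2ncnc(Nc3cccc(Cl)c3)c2c1`: > 1000 nM, again only a limit.

All three values sit at the limit of > 1000 nM in this assay, at which 3 of the 3 values shown sit, so none of them is a measured number. The change from compound 1 to compound 2 is methoxy in place of hydrogen on an aromatic carbon, and the step it made, a step that the two limits leave unreadable from compound 1 to compound 2, cannot be read in size because both ends are limits. The two cores differ by hydrogen in place of fluoro on an aromatic carbon, with the step that the two limits leave unreadable from compound 1 to compound 3 equally unreadable. Compound 4 `COc1cc2ncnc(Nc3cccc(Cl)c3)c2cc1B(O)O` has not yet been measured in this assay . It arises from compound 3 through (methoxy in place of hydrogen on an aromatic carbon), the same change that turns compound 1 into compound 2, set at the same place. Given that every value so far sits at the limit of > 1000 nM in this assay, at which 3 of the 3 values shown sit, compound 4 is expected to stay at the limit too, an estimated step that the limit leaves unreadable from compound 3 to compound 4. The estimate for compound 4 in this assay is 3000 nM, within an expected range from 1000 nM to 10000 nM.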

Compound 4, half-maximal inhibitory concentration: > 1000 nM
Compound 4: a limit, no number; the forecaster's own chance of this, stated with the estimate: 85%; the middle value lies beyond the limit too.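

No step can be read from compound 3 to compound 4 or from compound 2 to compound 4, since every value in these pairs is a limit of the assay and not a number: the limit of > 1000 nM in this assay, at which 4 of the 4 values shown sit.

The compounds shown leave open how strongly any of the four inhibits the receptor in this assay, and whether methoxy in place of hydrogen or hydrogen in place of fluoro changes that inhibition at all.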